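This account rests on a few compounds, and the source may have more. Where it says the series, first, only, none or still open, it means among the compounds named here.

The measured compounds:
compound 1, `COc1ccc(SCc2ccc(/C=C/C(=O)Nc3ccccc3N)cc2)cc1OC`, 46.4%
compound 2, `Nc1ccccc1NC(=O)/C=C/c1ccc(CSc2ccc(F)cc2)cc1`, 24.6%
compound 3, `Nc1ccccc1NC(=O)/C=C/c1ccc(CSc2cccc(F)c2)cc1`, 9.08%

In a functional assay on A-375 cells (Homo sapiens) for inhibition, read by CCK-8 assay, with a stated time of 72 h, tested at 8 uM (a lower number here means less inhibition of growth, a higher number more inhibition of growth at the concentration tested), compound 1 gives 46.4%, compound 2 gives 24.6% and compound 3 gives 9.08%. Compound 3 stands lowest of the three: the step of a number 15.5 percentage points lower from compound 2 to compound 3 (beyond the scatter) and the step of a number 37.3 percentage points lower from compound 1 to compound 3 (beyond the scatter) both lie beyond the scatter.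

Compound 4, `CC(C)(C)c1ccc(SCc2ccc(/C=C/C(=O)Nc3ccccc3N)cc2)cc1`, differs from compound 3 in one place: 4-(tert-butyl)phenyl in place of 3-fluorophenyl on a sulfur. Within the data shown here, no measured step puts a 4-(tert-butyl)phenyl on the sulfur, so the expectation rests on the two steps that end at compound 3. Both placed 3-fluorophenyl on that sulfur and both lowered the number, one modestly (a number 15.5 percentage points lower from compound 2 to compound 3 (beyond the scatter)) and one by a large amount (a number 37.3 percentage points lower from compound 1 to compound 3 (beyond the scatter)). Read the other way round, leaving 3-fluorophenyl for another group on the sulfur has each time raised the number beyond the scatter. A rise beyond the scatter is therefore expected for compound 4 as well. From the compounds shown here alone, its size remains open, as neither of the groups seen so far in that place is 4-(tert-butyl)phenyl. Compound 4 is estimated to give 26%, with a range from 9% to 45%. The expected step, a number 16.9 percentage points higher from compound 3 to compound 4 (beyond the scatter), would thus lie beyond the scatter.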

Compound 4, percent growth inhibition at one concentration: 35.5%
Beside the measured number, compound 4's estimate is 9.5 percentage points below it; low and high end bracket the measured number.
By their numbers in this assay, from the lowest: compound 3; then compound 2; then compound 4; then compound 1.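

In this assay, 4-(tert-butyl)phenyl on the sulfur, a group with neither fluoro nor methoxy, gives a number 26.4 percentage points higher from compound 3 to compound 4 (beyond the scatter), so all three other groups seen in this place now stand above 3-fluorophenyl. The step of a number 10.9 percentage points higher from compound 2 to compound 4 (beyond the scatter) shows that tert-butyl in place of fluoro on an aromatic carbon also raises the number, although the rise is modest, while the step of a number 10.9 percentage points lower from compound 1 to compound 4 (beyond the scatter) leaves the 3,4-dimethoxyphenyl of compound 1 highest of the four, with all its steps beyond the scatter. So a group with only carbon atoms can come closer to compound 1 than either fluorinated compound does, but no measurement shown here accounts for this order.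

The compounds shown leave open how an amine or a carboxylic acid on the aromatic ring attached to the sulfur would read, since only fluoro, methoxy and tert-butyl groups appear there. They also leave open whether a longer chain in place of the saturated chain carbon on the sulfur would keep this order, and whether the order would hold at another concentration.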